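The compounds below may be only part of what the source reports. "The series", "measured", "known", "first", "only" and "open" are said of these compounds alone.

Compound 1 `CCOC(=O)c1cnc(-c2ccccc2)s1` is the starting point here. In an assay on HEK293 cells for inhibition of transient receptor potential cation channel subfamily M member 8 (Homo sapiens), read by FLIPR, with stated times of 5 min and 3 min (on this read-out lower numbers stand for stronger inhibition and higher numbers for weaker inhibition), compound 1 reaches only a limit of the assay, > 100000 nM, so it sits at the limit of > 100000 nM in this assay, at which 1 of the 2 values shown sits, rather than at a measured number. Compound 2 `CCn1nnc(-c2sc(-c3cccc(C)c3)nc2O)n1` in this assay gives 369 nM. Compound 3 `CCOC(=O)c1sc(-c2ccccc2)nc1N` differs from compound 1 by amino in place of hydrogen on an aromatic carbon. Among the measured compounds shown here, no step between two measured compounds covers this change, so the expectation rests on compound 1 alone. The step of an at least 2.0-fold lower number from compound 1 to compound 3 (0.30 log units; that floor lies within the scatter) is expected to be modest, if any, with compound 3 likely staying weak. Compound 3 is therefore estimated at 50000 nM, within a range from 5000 nM to 200000 nM.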

Compound 3, half-maximal inhibitory concentration: > 100000 nM
Compound 3 ended at the assay's limit (the forecaster's own chance of this, stated with the estimate: 60%); middle value at least 2.0-fold (0.30 log units) from the limit.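

No step can be read between compound 1 and compound 3, since each gives a limit rather than a number: the limit of > 100000 nM in this assay, at which 2 of the 3 values shown sit. As far as these compounds go, whether amino in place of hydrogen changes inhibition at all stays open.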